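The source may hold more compounds than are shown below. What is called first, only, known or untested is meant among the compounds shown, and "the series" means these compounds.

Of the compounds shown here, two sharing one core have been tested in a functional assay on A2058 cells (Homo sapiens) for cytotoxicity, read by MTT assay, with a stated time of 24 h; on this read-out lower numbers stand for stronger inhibition and higher numbers for weaker inhibition. Compound 1 `CCCCCCCCCC[C@H](C(=O)O)[C@@](O)(Cc1ccc(O)cc1)C(=O)O` carries a long saturated chain, and in this assay compound 1 gives 26000 nM. Compound 2 `CCCCCCCCCCC[C@H](C(=O)O)[C@@](O)(Cc1ccc(O)cc1)C(=O)O` has that chain lengthened by one carbon, and in this assay compound 2 gives 3200 nM, the lower of the two numbers, placing compound 2 as the stronger of the pair. Among the compounds with values here, the only measured step, an 8.1-fold lower number from compound 1 to compound 2 (0.91 log units; beyond the scatter), bears directly on what comes next. Compound 3 `CCCCCCCCCCCC[C@H](C(=O)O)[C@@](O)(Cc1ccc(O)cc1)C(=O)O` differs from compound 2 by methyl in place of hydrogen on a saturated chain carbon, ten or more bonds along the chain from a carbonyl carbon. Within the data shown here, because an 8.1-fold lower number from compound 1 to compound 2 (0.91 log units; beyond the scatter) lay beyond the scatter, a further drop in this assay is expected for compound 3, though no second measured step shows whether such a gain continues, so a smaller drop is assumed. The step expected for compound 3 is a 2.5-fold lower number from compound 2 to compound 3 (0.39 log units; beyond the scatter). Compound 3 is therefore estimated at 1300 nM, with a range from 400 nM to 5000 nM.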

Compound 3, half-maximal inhibitory concentration: 30000 nM
Compound 3: middle estimate off by 23-fold (1.36 log units), on the low side, outside the stated range (above it).
By their numbers in this assay, from the lowest: compound 2; then compounds 1 and 3 (each within the scatter of the next).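

The same change that lowered the number before now raises it, giving a 9.4-fold higher number from compound 2 to compound 3 (0.97 log units; beyond the scatter) in this assay, so methyl in place of hydrogen at this place on the saturated chain does not act in one fixed direction. Ethyl in place of hydrogen, the change that links the other two compounds, gives a 1.2-fold higher number from compound 1 to compound 3 (0.06 log units; within the scatter) in this assay, so the shortest and longest chains shown cannot be told apart. Compound 2 alone stands apart, with steps beyond the scatter to both neighbours, and nothing measured here accounts for this turn.

From the compounds shown here alone, it remains open whether a longer chain would keep the number high or lower it again. Going by these compounds, what an amine or a carboxylic acid in place of that methyl would do also remains open.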